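Oxazolone-core acid series: lipophilicity notes toward compound 4

The compounds below may be only part of what the source reports. "The series", "measured", "known", "first", "only" and "open" are said of these compounds alone.

Measured so far:
- compound 1, `C[C@@H](Oc1cc2ccn(CCC(=O)O)c2cc1Cl)c1ccccn1`: 2.17
- compound 2, `C[C@@H](Oc1cc2onc(CCC(=O)O)c2cc1Cl)c1ccc(Cl)cn1`: 2.91
- compound 3, `O=C(O)CCn1c(=O)oc2cc(OCc3ccccn3)c(Cl)cc21`: 1.32

The three measured compounds were read in a physicochemical assay for lipophilicity, read by HPLC, at pH 7.4; a lower number here means a more polar compound, a higher number a more lipophilic compound. Compound 3 stands lowest of the three numbers. Its nearest neighbour in this assay is compound 1, which gives 2.17, a number beyond the scatter above compound 3; furthest is compound 2, which gives 2.91, also beyond the scatter. Compounds 1 and 2 differ from compound 3 in more than one place, so none of these gaps can be tied to a single structural change.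

Compound 4, `C[C@@H](Oc1cc2oc(=O)n(CCC(=O)O)c2cc1Cl)c1ncccn1`, shares the core of compound 3 and differs from it only at the side chain on the aromatic oxygen: a group of 8 heavy atoms (6 carbon, 2 nitrogen; one six-membered aromatic ring with 2 hetero atoms) in place of a group of 7 heavy atoms (6 carbon, 1 nitrogen; one six-membered aromatic ring with 1 hetero atom), on an oxygen on an aromatic ring

For the measured compounds named here, no single-change step within the measured set shows what this kind of exchange does in this assay. With one heavy atom more and one ring nitrogen more, the two parts of the change pull in opposite senses on the usual reasoning, and neither is supported by a measured step here. The step is therefore expected to be small, not beyond the scatter, and its expected size is a number 0.03 log units higher from compound 3 to compound 4 (within the scatter). Compound 4 is accordingly estimated at 1.35 in this assay, with a range from 0.9 to 1.8.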

Compound 4, distribution coefficient: 0.83
The estimate for compound 4 lay 0.52 log units above the measured number; measured number outside the range, below it.
By their numbers in this assay, from the lowest: compound 4; then compound 3; then compound 1; then compound 2.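

For the compounds shown here, the exchange of (pyridin-2-yl)methyl for the group of 8 heavy atoms, on an oxygen on an aromatic ring, gives the first single-change step for this assay: a number 0.49 log units lower from compound 3 to compound 4 (beyond the scatter). The position therefore responds to this change in this assay, and the direction is downward even though the entering group has the larger heavy-atom count, so on this one pair that count does not set the direction. No measurement available here explains the step, and its cause remains unassigned.

The change brings in the one six-membered aromatic ring with 2 hetero atoms and the 1 defined stereocentre together, so this single step cannot divide its size between them, and a (pyrimidin-2-yl)methyl group on the same oxygen, on the core of compound 3, would separate the two. On these data alone, whether the same exchange gives a step of similar size and direction on the core of compound 1 or compound 2 also remains open.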